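The compounds below may be only part of what the source reports. "The series", "measured", "known", "first", "only" and "open" are said of these compounds alone.

Compound 3 `Cn1c(=O)c2c(cc(/C=C/c3cccc(C#N)c3)n2C)n(C)c1=O` stands at the edge of what an assay on isolated protein for inhibition of Amine oxidase [flavin-containing] B (Homo sapiens), read by luminescence, with a stated time of 1 h (a lower number here means a stronger inhibitor, a higher number a weaker inhibitor), can report: in this assay compound 3 gives > 10000 nM, which is a limit of the measurement and not a number, the same as the limit of > 10000 nM in this assay, at which 1 of the 3 values shown sits. Its two neighbours carry numbers. Compound 1 `Cn1c(=O)c2c(cc(/C=C/c3cccc(Cl)c3)n2C)n(C)c1=O` gives 1480 nM in this assay, and compound 2 `COc1cccc(/C=C/c2cc3c(c(=O)n(C)c(=O)n3C)n2C)c1` gives 370 nM. Both steps toward compound 3 lie beyond the scatter: an at least 6.7-fold higher number from compound 1 to compound 3 (0.82 log units; beyond the scatter) and an at least 27-fold higher number from compound 2 to compound 3 (1.43 log units; beyond the scatter), while a 4.0-fold lower number from compound 1 to compound 2 (0.60 log units; beyond the scatter). Compound 4 `Cn1c(=O)c2c(cc(/C=C/c3cccc(O)c3)n2C)n(C)c1=O` differs from compound 3 by hydroxy in place of cyano on an aromatic carbon. The step from compound 2 to compound 3 bears most on this change, methoxy and hydroxy being the two oxygen groups in the set, and its reversal would carry compound 4 well clear of the limit. The smaller hydroxy need not recover all of that ground, so the expected step of an at least 12-fold lower number from compound 3 to compound 4 (1.09 log units; beyond the scatter) is read as a clear gain in potency rather than a full return. Compound 4 is therefore expected to give about 800 nM in this assay, within a range from 200 nM to 4000 nM.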

Compound 4, half-maximal inhibitory concentration: > 1000 nM
Compound 4 gave a limit, no number; the forecaster's own chance of this, stated with the estimate: 10%; middle value at least 1.2-fold (0.09 log units) away from the limit.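

In this assay compound 4 gives > 1000 nM, which is a limit of the measurement and not a number: the limit of > 1000 nM in this assay, at which 1 of the 4 values shown sits.

Even so, hydrogen in place of methyl on the oxygen gives an at least 2.7-fold higher number from compound 2 to compound 4 (0.43 log units; beyond the scatter), so at this position the methyl of the methoxy group matters, and an oxygen on this aromatic carbon is not enough on its own to hold the value of compound 2. The steps from compound 1 and from compound 3 to compound 4 cannot be read, so hydroxy cannot be ranked against chloro or cyano.

From the compounds shown here alone, how far compound 4 lies past its limit remains open. So does whether an ethoxy group, a longer ether chain or an amine on this aromatic carbon would match methoxy or fall away as hydroxy does.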